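Amide tail variation on the shared core

The compounds below may be only part of what the source reports. "The series", "measured", "known", "first", "only" and "open" are said of these compounds alone.

compound 1 `C=CC(=O)Nc1cccc(Nc2nc(Nc3ccc(OCC(=O)NCC(=O)O)cc3)ncc2Cl)c1`: a limit only in a functional assay on Ramos cells (Homo sapiens) for antiproliferative activity, read by CCK-8 assay, with a stated time of 72 h (on this read-out higher numbers stand for weaker inhibition and lower numbers for stronger inhibition), > 40000 nM
compound 2 `C=CC(=O)Nc1cccc(Nc2nc(Nc3ccc(OCC(=O)N4CCCC4C(=O)OC)cc3)ncc2Cl)c1`: 19700 nM in this assay

Among the measured compounds shown here, compound 2 holds the only full number in this assay; the other value is a limit. For the measured compounds named here, the single measured step, an at least 2.0-fold lower number from compound 1 to compound 2 (0.30 log units; that floor lies within the scatter), rests on that limit of > 40000 nM in this assay, at which 1 of the 2 values shown sits, and fixes only a floor. Compound 3 `C=CC(=O)Nc1cccc(Nc2nc(Nc3ccc(OCC(=O)NC(C)C(=O)OC)cc3)ncc2Cl)c1` differs from compound 2 by (1-(methoxycarbonyl)ethyl)amino in place of 2-(methoxycarbonyl)pyrrolidin-1-yl on a carbonyl carbon. Going by the values given here, compound 3 keeps the methyl ester of compound 2 while regaining an amide hydrogen as in compound 1; no measured step covers this exact exchange. Compound 3 is expected to stay close to compound 2, with a 1.3-fold higher number from compound 2 to compound 3 (0.10 log units; within the scatter) not clearly beyond the scatter. Compound 3 is estimated at 25000 nM, between 9000 nM and 60000 nM.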

Compound 3, half-maximal inhibitory concentration: 40800 nM
Estimate against measurement, compound 3: 1.6-fold (0.21 log units) below, within the range that was stated.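

In this assay, among the compounds shown here, (1-(methoxycarbonyl)ethyl)amino in place of 2-(methoxycarbonyl)pyrrolidin-1-yl on a carbonyl carbon gives a 2.1-fold higher number from compound 2 to compound 3 (0.32 log units; beyond the scatter), the first step at this place with full numbers at both ends. The ring-bearing tail, without an amide hydrogen, therefore holds the lower number. Compound 1 has only a limit, so its step to compound 3 cannot be read: the limit of > 40000 nM in this assay, at which 1 of the 3 values shown sits.

The exchange changes the ring and the amide hydrogen together, and these compounds do not separate the two. Going by these compounds, how a pyrrolidine tail ending in a free carboxylic acid or a primary amide would read remains open.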